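Working notes: amine side chains and cell tolerance

The compounds below may be only part of what the source reports. "The series", "measured", "known", "first", "only" and "open" are said of these compounds alone.

Measured compounds:
compound 1 `Cc1ccccc1-c1nn(-c2cccc(Cl)c2)cc1CNCCN1CCN(C)CC1`: 16000 nM
compound 2 `Cc1ccccc1-c1nn(-c2ccc(F)cc2F)cc1CNCCCCO`: > 20000 nM

In an ADME assay on Huh-7 cells (Homo sapiens) for cytotoxicity (a higher number here means that more compound is tolerated, a lower number that less compound is tolerated), compound 1 gives 16000 nM. For compound 2 only a limit is known; its reading of > 20000 nM is a limit of the assay, not a number, and it sits at the limit of > 20000 nM in this assay, at which 1 of the 2 values shown sits. Compound 3 `Cc1ccccc1-c1nn(-c2ccc(F)cc2F)cc1CNCCN1CCCCC1` differs from compound 2 by piperidin-1-yl in place of 2-hydroxyethyl on a saturated chain carbon, two bonds along the chain from an amine nitrogen. Within the data shown here, no measured pair isolates this change, so the step in this assay is not fixed by the data; a small move toward less compound tolerated, possibly not beyond the scatter, is expected. For compound 3 the estimate is 15000 nM, within 7000 nM to 30000 nM. That estimate corresponds to an expected step of an at least 1.3-fold lower number from compound 2 to compound 3 (0.12 log units; that floor lies within the scatter).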

Compound 3, half-maximal cytotoxic concentration: > 20000 nM
Compound 3: a limit, no number; the forecaster's own chance of this, stated with the estimate: 35%; middle value at least 1.3-fold (0.12 log units) from the limit.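

No step can be read from compound 2 to compound 3, as both readings in this assay are limits, not numbers: the limit of > 20000 nM in this assay, at which 2 of the 3 values shown sit.

The compounds shown leave open whether piperidin-1-yl in place of 2-hydroxyethyl changes the reading in this assay at all.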